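Phenyl for Indolyl on Two Related Antagonists

The source may report more compounds than this note shows. Statements on the series, on what has been measured and on what is new or still open speak of the compounds shown alone.

Two measured compounds set the scene. Compound 1 `COc1ccc(Cn2c(CCc3c[nH]c4ccccc34)nnc2[C@H](NC(=O)c2ccccn2)c2c[nH]c3ccccc23)c(OC)c1` and compound 2 `COc1ccc(Cn2c(CCc3ccccc3)nnc2[C@H](NC(=O)c2ccccn2)c2c[nH]c3ccccc23)c(OC)c1` share a core and differ only by phenyl in place of 1H-indol-3-yl on a saturated chain carbon, two bonds along the chain from an aromatic carbon. In a functional assay on CHO cells for antagonist activity at growth hormone secretagogue receptor type 1 (Homo sapiens) (on this read-out higher numbers stand for weaker inhibition and lower numbers for stronger inhibition), compound 1 gives 19 nM, while compound 2 gives 25 nM. The step of a 1.3-fold higher number from compound 1 to compound 2 (0.12 log units; within the scatter) is small, so the two numbers cannot be told apart with confidence.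

Compound 3 `COc1ccc(Cn2c(CCc3c[nH]c4ccccc34)nnc2[C@H](NC(=O)c2cnccn2)c2c[nH]c3ccccc23)c(OC)c1` carries the core of compound 1 with one change, (pyrazin-2-yl in place of pyridin-2-yl on a carbonyl carbon). In this assay compound 3 gives 97 nM, and the step of a 5.1-fold higher number from compound 1 to compound 3 (0.71 log units; beyond the scatter) is the only one among these three compounds that clearly moves the number, giving compound 3 the highest value of the three.

Compound 4 `COc1ccc(Cn2c(CCc3ccccc3)nnc2[C@H](NC(=O)c2cnccn2)c2c[nH]c3ccccc23)c(OC)c1` has not yet been measured. It differs from compound 3 by phenyl in place of 1H-indol-3-yl on a saturated chain carbon, two bonds along the chain from an aromatic carbon, which is the same change already seen from compound 1 to compound 2, made at the same place and occurring twice among the compounds here. The two cores differ by the change just described for compound 3, so compound 4 is the counterpart of compound 2 on that core. Because the earlier step of a 1.3-fold higher number from compound 1 to compound 2 (0.12 log units; within the scatter) stayed within the scatter, the expected step from compound 3 is a 1.2-fold higher number from compound 3 to compound 4 (0.09 log units; within the scatter), and an estimate in this assay for compound 4 is about 120 nM, expected to fall between 50 nM and 300 nM.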

Compound 4, antagonist equilibrium constant: 24 nM
Compound 4: the middle estimate sits 5.0-fold (0.70 log units) above what was measured; measured number below the stated range.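

The change from 1H-indol-3-yl to phenyl did not carry over from one core to the other in this assay: on the pyrazin-2-yl core it gave a 4.0-fold lower number from compound 3 to compound 4 (0.61 log units; beyond the scatter), and this step differs from the one seen on the pyridin-2-yl core: the same change on two cores in this assay, a 1.3-fold higher number (0.12 log units; within the scatter) from compound 1 to compound 2 and a 4.0-fold lower number (0.61 log units; beyond the scatter) from compound 3 to compound 4, 5.3-fold (0.73 log units) apart, beyond the scatter of two such steps The change from pyridin-2-yl to pyrazin-2-yl also depends on its setting, since with phenyl in place of 1H-indol-3-yl it gives a 1.0-fold lower number from compound 2 to compound 4 (0.02 log units; within the scatter), and this differs from the step seen when the indole is present: the same change on two cores in this assay, a 5.1-fold higher number (0.71 log units; beyond the scatter) from compound 1 to compound 3 and a 1.0-fold lower number (0.02 log units; within the scatter) from compound 2 to compound 4, 5.3-fold (0.73 log units) apart, beyond the scatter of two such steps Among these four compounds, then, the two changes do not act independently, so the step seen for one change on one core is a poor guide to the same change on the other, although the data do not show why this happens or whether it holds beyond this set.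

On these data alone, it remains open whether the same dependence would appear with other groups, such as cyclohexyl in place of phenyl on the chain or pyrimidin-2-yl on the carbonyl carbon. A longer chain carrying the phenyl group is a further open case, and so is an amine on that chain.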